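Two trimethoxyphenyl pyrazole chalcones at the assay limit

This account rests on a few compounds, and the source may have more. Where it says the series, first, only, none or still open, it means among the compounds named here.

Compound 1: `COc1cc(-c2cc(/C=C/C(=O)c3ccc(N)cc3)[nH]n2)cc(OC)c1OC` — > 100000 nM
Compound 2: `COc1cc(-c2cc(/C=C/C(=O)c3ccc(Cl)c(Cl)c3)[nH]n2)cc(OC)c1OC` — > 100000 nM

In a functional assay on Hs-578T cells (Homo sapiens) for inhibition, read by sulforhodamine B assay, with a stated time of 48 h (a higher number here means a weaker inhibitor of growth, a lower number a stronger inhibitor of growth), compound 1 gives only a limit, > 100000 nM. Compound 2 likewise sits at a limit, > 100000 nM. The step that the two limits leave unreadable from compound 1 to compound 2 therefore cannot be read, and the limit of > 100000 nM in this assay, at which 2 of the 2 values shown sit, is all the evidence the two measurements offer. Compound 3 is `COc1ccc(C(=O)/C=C/c2cc(-c3cc(OC)c(OC)c(OC)c3)n[nH]2)cc1OC`, differing from compound 2 by 3,4-dimethoxyphenyl in place of 3,4-dichlorophenyl on a carbonyl carbon. Going by the values given here, no measured step bears on this exchange, so no direction can be drawn from it. Because compound 2 stands at the limit > 100000 nM, compound 3 is expected to remain near that limit as well, giving an estimated step of a number no higher from compound 2 to compound 3 (the limit leaves the size open). Compound 3 is estimated at 100000 nM, in the range 30000 nM to 300000 nM.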

Compound 3, concentration for total growth inhibition: 8200 nM
For compound 3 the middle estimate is 12-fold (1.09 log units) above the measured one, outside the stated range (below it).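

On a carbonyl carbon, 3,4-dimethoxyphenyl is the only group shown that gives a value clear of the limit in this assay: in place of 3,4-dichlorophenyl it gives an at least 12-fold lower number from compound 2 to compound 3 (1.08 log units; beyond the scatter), and in place of 4-aminophenyl it gives an at least 12-fold lower number from compound 1 to compound 3 (1.08 log units; beyond the scatter). Both steps give only a smallest size, and the step between the other two compounds cannot be read, because each of those compounds sits at a limit: the limit of > 100000 nM in this assay, at which 2 of the 3 values shown sit.

As far as these compounds go, what 4-methoxyphenyl or 3,4-dihydroxyphenyl would give on that carbonyl carbon stays open. So does whether the number falls further with 3,4,5-trimethoxyphenyl there.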